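The compounds below may be only part of what the source reports. "The series", "measured", "known", "first", "only" and "open" are said of these compounds alone.

Measured in a functional assay on M14 cells (Homo sapiens) for inhibition, read by sulforhodamine B assay, with a stated time of 48 h, tested at 10 uM; on this read-out higher numbers stand for more inhibition at the one concentration tested (going by the name of the read-out) and lower numbers for less inhibition:
compound 1 `c1ccc(-c2cn3ccnc3c(-c3ccc4ncn(C5CCCCC5)c4c3)n2)cc1` gives 38.2%
compound 2 `O=Cc1ccc(-c2cn3ccnc3c(-c3ccc4ncn(C5CCCCC5)c4c3)n2)cc1` gives 23%
compound 3 `Fc1ccc(-c2cn3ccnc3c(-c3ccc4ncn(C5CCCCC5)c4c3)n2)cc1` gives 2.98%

Compound 3 stands lowest of the three numbers in this assay; compound 2 is its nearest neighbour and compound 1 its furthest, both beyond the scatter. The two measured steps that reach compound 3 both run downward: a number 35.2 percentage points lower from compound 1 to compound 3 (beyond the scatter) and a number 20 percentage points lower from compound 2 to compound 3 (beyond the scatter). The remaining step, a number 15.2 percentage points lower from compound 1 to compound 2 (beyond the scatter), shows that in both cases seen a group entering on an aromatic carbon of the unsubstituted compound 1 lowered the number.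

Compound 4 `Clc1ccc(-c2cn3ccnc3c(-c3ccc4ncn(C5CCCCC5)c4c3)n2)cc1` has not yet been measured. It differs from compound 3 in one place: chloro in place of fluoro on an aromatic carbon. Among the compounds with values here, no measured step swaps one halogen for another, so the bearing of the known steps is indirect: each group set on that aromatic carbon gave a lower number than compound 1, and fluoro gave the lowest. A chloro group at the same aromatic carbon is expected to leave compound 4 near the bottom of the series, with a step of a number 5 percentage points higher from compound 3 to compound 4 (within the scatter) expected to stay within the scatter. The estimate for compound 4 in this assay is 8%, with a range from -5% to 25%.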

Compound 4, a percentage reported as inhibition, at one concentration (the size of the read-out at that concentration, not a potency): 10%
Compound 4: the middle estimate sits 2 percentage points below what was measured, and the stated range covers the measured number.
By their numbers in this assay, from the lowest: compounds 3 and 4 (each within the scatter of the next); then compound 2; then compound 1.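

In this assay the change from 4-fluorophenyl to 4-chlorophenyl gives a number 7 percentage points higher from compound 3 to compound 4 (within the scatter) on an aromatic carbon para to a large group, so the two halogens cannot be told apart on this read-out. Chloro gives a number 13 percentage points lower from compound 2 to compound 4 (beyond the scatter) when it replaces formyl and a number 28.2 percentage points lower from compound 1 to compound 4 (beyond the scatter) when it replaces hydrogen, so the low result is no longer confined to fluoro, and all three groups seen at this carbon now fall beyond the scatter from hydrogen. Nothing available explains these steps or the similarity of the two halogens.

Formyl is the only non-halogen group shown at this carbon, so it remains open whether the loss belongs to halogens, to substitution here in general, or to something else, and an amine, a methoxy group or a carboxylic acid at the same carbon would help to separate these readings. Also open, going by these compounds, is whether any group at this carbon can match or exceed hydrogen, and how these single-concentration percentages relate to potency.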